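The compounds below may be only part of what the source reports. "The series", "measured", "known", "first", "only" and "open" are said of these compounds alone.

The measured compounds in an assay on CHO cells for displacement of a labelled ligand from muscarinic acetylcholine receptor M5 (Homo sapiens); a higher number here means a weaker inhibitor, a lower number a stronger inhibitor:
Compound 1 `CN(C)C[C@@H]1CN(C)C(=O)O1` gives > 100000 nM, which is a limit of the assay.
Compound 2 `CN1C[C@@H](C[N+](C)(C)C)OC1=O` gives > 100000 nM, which is likewise a limit of the assay.

Compound 1 thus stands at the limit of this assay, with no number to place it. Compound 3 `CN(C)C[C@@H]1CNC(=O)O1` has not been measured in this assay; it differs from compound 1 by hydrogen in place of methyl on an amide-type nitrogen in a ring. For the measured compounds named here, the one measured step, a step that the two limits leave unreadable from compound 1 to compound 2, alters a different part of the shared core and cannot be read because the limit of > 100000 nM in this assay, at which 2 of the 2 values shown sit, holds for both compounds. Going by the values given here, no measured step therefore bears on the change to compound 3, and no number of compound 1 gives a scale. Compound 3 is expected to remain at the limit, so the step of a number no higher from compound 1 to compound 3 (the limit leaves the size open) is an expectation of no change beyond the scatter. For compound 3 the estimate is 100000 nM, within 50000 nM to 300000 nM.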

Compound 3, inhibition constant: > 100000 nM
Compound 3 gave a limit, no number (the forecaster's own chance of this, stated with the estimate: 85%); the middle value lies on the limit itself.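

In this assay compound 3 gives > 100000 nM, which is a limit and not a number. The change from compound 1 to compound 3 therefore yields no readable step: the limit of > 100000 nM in this assay, at which 3 of the 3 values shown sit.

The compounds shown leave open which change to the shared core, if any, would give a number in this assay.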